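From octyl to phenethyl: an expected cell-growth readout

The source may report more compounds than this note shows. Statements on the series, on what has been measured and on what is new or still open speak of the compounds shown alone.

Compound 1 `O=c1cc(Cn2cc(C3CC3)nn2)c2ccc(O)cc2o1` gives 91700 nM in a functional assay on A549 cells (Homo sapiens) for inhibition, read by MTT assay, with a stated time of 72 h; on this read-out lower numbers stand for stronger inhibition and higher numbers for weaker inhibition. Compound 2 `O=c1cc(Cn2cc(CCCCO)nn2)c2ccc(O)cc2o1` returns only a limit of the assay, > 100000 nM. Compound 3 `CCCCCCCCc1cn(Cc2cc(=O)oc3cc(O)ccc23)nn1` gives 46000 nM.

Among the numbers shown, compound 3 carries the lowest one; its nearest neighbour is compound 1, and the step of a 2.0-fold lower number from compound 1 to compound 3 (0.30 log units; within the scatter) stays within the scatter. The step of an at least 2.1-fold lower number from compound 2 to compound 3 (0.33 log units; beyond the scatter) is at least modest, but it starts from a limit of > 100000 nM in this assay, at which 1 of the 3 values shown sits, rather than a number. The step of an at least 1.0-fold higher number from compound 1 to compound 2 (0.03 log units; that floor lies within the scatter) likewise rests on that limit.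

Compound 4 `O=c1cc(Cn2cc(CCc3ccccc3)nn2)c2ccc(O)cc2o1` differs from compound 3 by phenyl in place of hexyl on a saturated chain carbon, two bonds along the chain from an aromatic carbon. Among the measured compounds shown here, no measured step swaps a chain for a ring; the nearest precedents change the tail on the aromatic carbon, and the one between two numbers, from compound 1 to compound 3, stays within the scatter. The expected step of a 1.2-fold higher number from compound 3 to compound 4 (0.08 log units; within the scatter) is therefore none beyond the scatter. Compound 4 is estimated at 55000 nM, with a range from 20000 nM to 150000 nM.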

Compound 4, half-maximal inhibitory concentration: 24800 nM
Estimate against measurement, compound 4: 2.2-fold (0.35 log units) above; low and high end bracket the measured number.
By their numbers in this assay, from the lowest: compounds 4, 3 and 1 (each within the scatter of the next, the first and the last beyond it). At a limit, above all of these: compound 2.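

In this assay, the step of a 1.9-fold lower number from compound 3 to compound 4 (0.27 log units; within the scatter) means that phenyl and hexyl cannot be told apart at this place, on a saturated chain carbon two bonds along the chain from an aromatic carbon. Among the compounds shown here, what is new is that a tail ending in a ring holds up as well as the long octyl chain, and that it gives the first step between two real numbers to go beyond the scatter: a 3.7-fold lower number from compound 1 to compound 4 (0.57 log units; beyond the scatter). The step of an at least 4.0-fold lower number from compound 2 to compound 4 (0.60 log units; beyond the scatter) is also beyond the scatter, but it gives only a floor, since compound 2 sits at a limit rather than a number: the limit of > 100000 nM in this assay, at which 1 of the 4 values shown sits.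

From the compounds shown here alone, it remains open how a shorter benzyl tail would compare with phenethyl. Going by these compounds, it is equally open what a chlorine on the phenyl ring, or an amine at the end of the chain, would do.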